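A few compounds are considered here, and "the series" means these few. Any claim that something is new, unique, unknown or untested is made for them only; others in the source may bear on it.

Of the compounds shown here, three sharing one core have been measured in an ADME assay on microsomes from liver (Mus musculus) for pharmacokinetics, read by LC-MS, using NADPH, with stated times of 5 min, 15 min and 30 min, tested at 10 uM; a lower number here means slower removal, a higher number faster removal of the compound. Compound 1 `C[C@H](NC(=O)c1cccc(F)c1)c1ccc(NC(=O)N2CC(c3cccnc3)C2)cc1` gives 60.9 mL.min-1.g-1, compound 2 `C[C@H](NC(=O)[C@@H]1CCCN1C)c1ccc(NC(=O)N2CC(c3cccnc3)C2)cc1` gives 40.8 mL.min-1.g-1 and compound 3 `CCC(=O)N[C@@H](C)c1ccc(NC(=O)N2CC(c3cccnc3)C2)cc1` gives 31.4 mL.min-1.g-1, so compound 1 stands within the scatter of both others. These three differ only in the group on a carbonyl carbon. The measured steps are a 1.5-fold lower number from compound 1 to compound 2 (0.17 log units; within the scatter), a 1.9-fold lower number from compound 1 to compound 3 (0.29 log units; within the scatter) and a 1.3-fold lower number from compound 2 to compound 3 (0.11 log units; within the scatter).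

Compound 4 `C[C@H](NC(=O)c1cccc(F)c1)c1ccc(NC(=O)N2CC(c3cncc(N)c3)C2)cc1` keeps the 3-fluorophenyl group of compound 1 and differs in another place: amino in place of hydrogen on an aromatic carbon. Seen one bond further out, pyridin-3-yl becomes 5-aminopyridin-3-yl. Going by the values given here, none of the measured steps touches this ring, and no measured compound carries the amino group, so the data offer no direct precedent. The three steps bear on it only indirectly, showing that replacing the group on the carbonyl carbon left the numbers in this assay within the scatter. On that limited evidence, no step beyond the scatter is expected, in either direction. The estimated step is a 1.2-fold lower number from compound 1 to compound 4 (0.07 log units; within the scatter). For compound 4 the expected value is 52 mL.min-1.g-1, with an estimated range of 26 mL.min-1.g-1 to 100 mL.min-1.g-1.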

Compound 4, intrinsic clearance in microsomes: 27.4 mL.min-1.g-1
The estimate for compound 4 lay 1.9-fold (0.28 log units) above the measured number, within the range that was stated.
By their numbers in this assay, from the lowest: compounds 4, 3, 2 and 1 (each within the scatter of the next, the first and the last beyond it).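

Going by these compounds alone, the pyridin-3-yl ring had not varied among the earlier compounds, and compound 4 gives the first reading of it: in this assay, amino in place of hydrogen on an aromatic carbon, two atoms from the ring nitrogen, gives a 2.2-fold lower number from compound 1 to compound 4 (0.35 log units; beyond the scatter), a modest step, whereas all three steps among the earlier compounds stayed within the scatter. This position therefore does register in this read-out, with the 3-fluorophenyl group kept and only one heavy atom, a nitrogen, entering the molecule. Nothing available here gives a reason for the step.

The compounds shown leave open whether the step belongs to the amino group as such or would also appear with a hydroxyl, a methoxy or a methylamino group at the same place. They also leave open whether it would hold with ethyl or 1-methylpyrrolidin-2-yl on the carbonyl carbon, since the amino group is read here only against the 3-fluorophenyl amide of compound 1.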